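Ring Size of the Ether Substituent and Receptor Binding

A few compounds are considered here, and "the series" means these few. Any claim that something is new, unique, unknown or untested is made for them only; others in the source may bear on it.

Compound 1 `CCCCCOc1cccc2ccc(N)nc12`: 580 nM
Compound 2 `Nc1ccc2cccc(OCC3CC3)c2n1`: > 2000 nM

In an assay on cells with melanin-concentrating hormone receptor 1 (Homo sapiens) as the target, read by radioligand binding (a lower number here means a stronger inhibitor, a higher number a weaker inhibitor), compound 1 gives 580 nM. For compound 2 the reading of > 2000 nM is a limit of the assay, not a number. Compound 2 thus sits at the limit of > 2000 nM in this assay, at which 1 of the 2 values shown sits, and the step of an at least 3.4-fold higher number from compound 1 to compound 2 (0.53 log units; beyond the scatter) is only a lower bound on the loss. Compound 3 `Nc1ccc2cccc(OCC3CCC3)c2n1` differs from compound 2 by cyclobutyl in place of cyclopropyl on a saturated chain carbon bound to an oxygen on an aromatic ring. For the measured compounds named here, the one measured step bearing on it, an at least 3.4-fold higher number from compound 1 to compound 2 (0.53 log units; beyond the scatter), points toward a modest gain for the cyclobutyl analogue, though with compound 2 at a limit the gain may be nil. Compound 3 is expected near 1500 nM, between 500 nM and 5000 nM, an estimated step of an at least 1.3-fold lower number from compound 2 to compound 3 (0.12 log units; that floor lies within the scatter).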

Compound 3, half-maximal inhibitory concentration: 432 nM
The estimate for compound 3 lay 3.5-fold (0.54 log units) above the measured number; the measured number lies below the stated range.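

In this assay, cyclobutyl in place of cyclopropyl at this place gives an at least 4.6-fold lower number from compound 2 to compound 3 (0.66 log units; beyond the scatter), so ring size matters here. Compound 2 stands at a limit, not a number, so that step is only a lower bound: the limit of > 2000 nM in this assay, at which 1 of the 3 values shown sits. Against the open chain of compound 1, the cyclobutyl ether shows a 1.3-fold lower number from compound 1 to compound 3 (0.13 log units; within the scatter), so a ring need not cost binding here, though compound 2 goes against this.

From the compounds shown here alone, whether a larger ring such as cyclopentyl or cyclohexyl would hold this level remains open. So does the effect of an amine on the ring.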